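The source may hold more compounds than are shown below. What is called first, only, known or untested is meant among the compounds shown, and "the series" means these compounds.

Compound 3 `O=C(O)[C@@H](CC1CCC1)N1C[C@H](CN2CCC(c3cnc4ccc(Cl)cn34)CC2)[C@@H](c2cccc(F)c2)C1` gives 16 mL/min/kg in an in vivo ADME assay on the whole organism (plasma, Rattus norvegicus) for pharmacokinetics; a lower number here means slower removal, a higher number faster removal of the compound. Compound 2 `O=C(O)[C@@H](CC1CCC1)N1C[C@H](CN2CCC(CCCc3ccccc3)CC2)[C@@H](c2ccccc2)C1` gives 27 mL/min/kg, a number that sits within the scatter of compound 3. For the measured compounds named here, compound 1 `O=C(O)[C@@H](CC1CCC1)N1C[C@H](CN2CCC(c3cnc4ccc([N+](=O)[O-])cn34)CC2)[C@@H](c2cccc(F)c2)C1` gives 120 mL/min/kg, and the single measured step, a 7.5-fold lower number from compound 1 to compound 3 (0.88 log units; beyond the scatter), separates it from compound 3 beyond the scatter. Compound 4 `O=C(O)[C@@H](CC1CCC1)N1C[C@H](CN2CCC(c3cnc4c(Cl)cc(Cl)cn34)CC2)[C@@H](c2cccc(F)c2)C1` differs from compound 3 by chloro in place of hydrogen on an aromatic carbon. Going by the values given here, no measured step exchanges hydrogen for chloro in this set; the one step available, a 7.5-fold lower number from compound 1 to compound 3 (0.88 log units; beyond the scatter), exchanged nitro for chloro, so it bears on the added chloro only loosely. Compound 4 is therefore expected to give a number near that of compound 3, with no step beyond the scatter, estimated as no change at the digits printed from compound 3 to compound 4 (within the scatter). The estimate for compound 4 is 16 mL/min/kg, ranging from 8 mL/min/kg to 35 mL/min/kg.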

Compound 4, clearance: 20 mL/min/kg
The estimate for compound 4 lay 1.3-fold (0.10 log units) below the measured number, and the stated range covers the measured number.
By their numbers in this assay, from the lowest: compounds 3, 4 and 2 (each within the scatter of the next); then compound 1.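

In this assay, chloro in place of hydrogen on the aromatic carbon ortho to a fused ring gives a 1.3-fold higher number from compound 3 to compound 4 (0.10 log units; within the scatter) and so stays within the scatter, which shows that this position accepts a second chloro with no clear shift in removal. The gap to the nitro compound also survives that addition, with a 6.0-fold lower number from compound 1 to compound 4 (0.78 log units; beyond the scatter) still lying beyond the scatter. From the compounds shown here alone, whether a methoxy, a nitrile or an amine at this position would leave the number as close to that of compound 3 remains open. Nothing measured here speaks to the reason for these numbers.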